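Chloro in Place of Nitro: What to Expect for Compound 4

The source may report more compounds than this note shows. Statements on the series, on what has been measured and on what is new or still open speak of the compounds shown alone.

Compound 1, `CCNc1ccc2c(c1)OC(N)=C(C#N)C2c1cccc([N+](=O)[O-])c1`, gives 110000000 nM in a functional assay on T47D cells (Homo sapiens) for activation; on this read-out lower numbers stand for an effect already at smaller amounts and higher numbers for an effect only at larger amounts of compound.
Compound 2, `CCNc1ccc2c(c1)OC(N)=C(C#N)C2c1cc(Br)c(OC)c(OC)c1`, gives 14000000 nM in this assay.
Compound 3, `COc1cccc(C2C(C#N)=C(N)Oc3cc(OC)ccc32)c1`, gives 52000000 nM in this assay.

Among these three numbers compound 1 stands highest. Compound 3 lies nearest to it, with a number lower than that of compound 1 by more than the scatter; compound 2 lies furthest, lower still. Compound 4, `CCNc1ccc2c(c1)OC(N)=C(C#N)C2c1cccc(Cl)c1`, has not yet been measured. It differs from compound 1 in one place: chloro in place of nitro on an aromatic carbon. Going by the values given here, no pair of measured compounds shows this exact change, so its effect can only be guessed from the spread of the three values. In this assay the step from compound 1 is expected to be modest and toward a lower number, partly because compound 2, which carries a bromo on that ring among other groups, gives 14000000 nM. The number for compound 4 is estimated at 50000000 nM, with a range from 15000000 nM to 160000000 nM. The step this estimate implies is expected to be a 2.2-fold lower number from compound 1 to compound 4 (0.34 log units; beyond the scatter).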

Compound 4, half-maximal effective concentration: 120000000 nM
Beside the measured number, compound 4's estimate is 2.4-fold (0.38 log units) below it, and the stated range covers the measured number.
By their numbers in this assay, from the lowest: compound 2; then compound 3; then compounds 1 and 4 (each within the scatter of the next).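

With chloro in place of nitro on the aromatic carbon, this assay shows a 1.1-fold higher number from compound 1 to compound 4 (0.04 log units; within the scatter) and so no readable shift at this position. The earlier compounds shown here could not show this, as no two of them differed in one place; here the number of heavy atoms and of hydrogen-bond acceptors on this carbon falls, yet the read-out stays within the scatter. Nothing at hand offers a reason for this result.

As far as these compounds go, whether an amine, a carboxylic acid or a longer chain on this carbon would leave the number just as unchanged remains open. Also open, from the compounds shown here alone, is whether chloro in place of nitro would give a step of the same size on the core of compound 3, or alongside the other groups on the aromatic ring of compound 2.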